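The source may report more compounds than this note shows. Statements on the series, on what has been measured and on what is new or still open speak of the compounds shown alone.

Compound 1 `O=C1O[C@@H](CN2CCCCC2)CN1c1ccc(-n2cc(-c3ccccn3)cn2)c(F)c1` stands second highest of the three compounds in a physicochemical assay for lipophilicity, read by HPLC, measured as octanol-water partition (on this read-out higher numbers stand for higher lipophilicity and lower numbers for lower lipophilicity), giving 3.1. Compound 3 `O=C(OC[C@H]1CN(c2ccc(-n3cc(-c4ccccn4)cn3)c(F)c2)C(=O)O1)c1ccccc1` gives 4.21, and compound 2 `O=C1CCC(=O)N1C[C@H]1CN(c2ccc(-n3cc(-c4ccccn4)cn3)c(F)c2)C(=O)O1` gives 1.58. Two measured steps change the same position: a number 1.52 log units lower from compound 1 to compound 2 (beyond the scatter), while a number 1.11 log units higher from compound 1 to compound 3 (beyond the scatter). Compound 4 `O=C1O[C@@H](Cn2ccnc2)CN1c1ccc(-n2cc(-c3ccccn3)cn2)c(F)c1` differs from compound 1 in 1H-imidazol-1-yl in place of piperidin-1-yl on a saturated chain carbon bound to a saturated ring carbon. The group entering is an aromatic five-membered ring with two hetero atoms and two hydrogen-bond acceptors, which resembles the direction of the step to compound 2 more than the step to compound 3, so a large drop in this assay is expected. Compound 4 is therefore expected to reach 1.9, with a range from 1.3 to 2.5, a step of a number 1.20 log units lower from compound 1 to compound 4 (beyond the scatter).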

Compound 4, partition coefficient: 1.73
Beside the measured number, compound 4's estimate is 0.17 log units above it; measured number inside the range.
By their numbers in this assay, from the lowest: compounds 2 and 4 (each within the scatter of the next); then compound 1; then compound 3.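

In this assay, a second replacement of piperidin-1-yl at this position also goes down, with 1H-imidazol-1-yl giving a number 1.37 log units lower from compound 1 to compound 4 (beyond the scatter). The step from the benzoyloxy compound is wider, a number 2.48 log units lower from compound 3 to compound 4 (beyond the scatter), while the step from the 2,5-dioxopyrrolidin-1-yl compound is a number 0.15 log units higher from compound 2 to compound 4 (within the scatter), so these two different groups cannot be told apart on this read-out. Nothing available here accounts for this result. The compounds shown leave open where morpholin-4-yl or a carboxylic acid on the same saturated chain carbon would stand among these values.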